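Chloro for Hydroxy on a Weakly Active Thiadiazole

The compounds below may be only part of what the source reports. "The series", "measured", "known", "first", "only" and "open" are said of these compounds alone.

Measured compounds:
compound 1 `O=C(CCC(=O)Nc1nnc(-c2ccc(O)cc2)s1)NO` — in a functional assay on PC-3 cells (Homo sapiens) for inhibition, read by MTT assay (a higher number here means a weaker inhibitor, a lower number a stronger inhibitor), compound 1 gives 14700 nM
compound 2 `NC(=O)N1N=C(c2ccccc2)CC1c1ccccc1OCC(=O)NO` — in this assay compound 2 gives 18700 nM

Among the compounds with values here, only two numbers are in hand, and both sit in the weak range. Compound 1 has the lower of the two, but compound 2 lies within the usual scatter of it, so the two cannot be placed in any order of strength. The two compounds also share no common core, so nothing can be said about which part of either structure matters.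

Compound 3 `O=C(CCC(=O)Nc1nnc(-c2ccc(Cl)cc2)s1)NO` keeps the core of compound 1 and differs in one place: chloro in place of hydroxy on an aromatic carbon. Within the data shown here, no measured pair differing in a single place is available to show what such a swap does here, so the expectation rests on compound 1 alone. The step of a 1.2-fold lower number from compound 1 to compound 3 (0.09 log units; within the scatter) is expected to stay within the scatter. Compound 3 is therefore estimated at 12000 nM, with a range from 4000 nM to 40000 nM.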

Compound 3, half-maximal inhibitory concentration: 14700 nM
Compound 3: middle estimate off by 1.2-fold (0.09 log units), on the low side; the measured number falls inside the stated range.
By their numbers in this assay, from the lowest: compounds 1, 3 and 2 (each within the scatter of the next).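

Within the data shown here, replacing 4-hydroxyphenyl with 4-chlorophenyl gives no change at the digits printed from compound 1 to compound 3 (within the scatter) in this assay, the first comparison here between compounds that differ in one place. At this position, on an aromatic carbon para to a large group, a hydroxy group with one hydrogen-bond donor and one acceptor can therefore give way to a chloro group with neither, and the number stays within the scatter. For this pair, the hydroxy group is thus not needed for the weak inhibition seen, but nothing available explains the result.

Going by these compounds, it remains open whether an amine or a carboxylic acid on this aromatic carbon would move the number beyond the scatter. On these data alone, it is also open whether chloro in place of hydroxy would give the same result on a different core.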